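Swapping Cyclopropyl for Azetidine on a Well-Tolerated Scaffold

The source may hold more compounds than are shown below. What is called first, only, known or untested is meant among the compounds shown, and "the series" means these compounds.

Compound 1 `CS(=O)(=O)CCCn1c(Cn2c(=O)n(C3CC3)c3ccncc32)cc2cc(Cl)ccc21` was tested in an ADME assay on HeLa cells (Homo sapiens) for cytotoxicity, read by ATP content, with a stated time of 3 days; a higher number here means that more compound is tolerated, a lower number that less compound is tolerated. In this assay compound 1 gives > 50000 nM, which is a limit of the assay rather than a number. Two close relatives were run alongside it. Compound 2 `O=c1n(Cc2cc3cc(Cl)ccc3n2CCCCO)c2cnccc2n1C1CC1` differs from compound 1 in one place; in this assay compound 2 gives > 50000 nM, again a limit. Compound 3 `CS(=O)(=O)CCCn1c(Cn2c(=O)n(C3CC3)c3ccncc32)cc2cc(C(F)(F)F)ccc21` also differs from compound 1 in one place; in this assay compound 3 gives > 50000 nM, once more a limit. The step that the two limits leave unreadable from compound 1 to compound 2 and the step that the two limits leave unreadable from compound 1 to compound 3 therefore cannot be sized, because of the limit of > 50000 nM in this assay, at which 3 of the 3 values shown sit.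

Compound 4 `CS(=O)(=O)CCCn1c(Cn2c(=O)n(C3CNC3)c3ccncc32)cc2cc(Cl)ccc21` is not yet measured. It differs from compound 1 in one place: azetidin-3-yl in place of cyclopropyl on an aromatic nitrogen. None of the measured steps touches this position, so no shown step says how tolerance responds to a change there. What the data do show is that each variation tried so far leaves the limit untouched, since (the limit of > 50000 nM in this assay, at which 3 of the 3 values shown sit). Compound 4 is therefore expected to give 50000 nM, within the range 15000 nM to 200000 nM. The expected step is a number no higher from compound 1 to compound 4 (the limit leaves the size open), that is, nothing beyond the scatter, with a good chance that only a limit is reported again.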

Compound 4, half-maximal cytotoxic concentration: > 50000 nM
Compound 4 ended at the assay's limit (the forecaster's own chance of this, stated with the estimate: 75%); the middle value lies on the limit itself.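

The change from cyclopropyl in compound 1 to azetidin-3-yl in compound 4 cannot be sized, and neither can the other steps, because every result is a limit of the assay rather than a number: (the limit of > 50000 nM in this assay, at which 4 of the 4 values shown sit). The compounds shown leave open at what concentration in this assay any of them would start to harm the cells.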